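A few compounds are considered here, and "the series" means these few. Any claim that something is new, unique, unknown or untested is made for them only; others in the source may bear on it.

In an ADME assay on microsomes from liver (Homo sapiens) for metabolic stability, read by LC-MS, using NADPH, with a stated time of 10 min, tested at 0.1 uM (a lower number here means slower removal, a higher number faster removal of the compound), compound 3 `O=C(NCCCCc1ccccc1)c1cccc(C2SCC(=O)N2c2ccccc2F)c1` gives 1710 mL.min-1.g-1. That sits within the scatter of compound 1 `Cc1cccc(N2C(=O)CSC2c2cccc(C(=O)NCCCCc3ccccc3)c2)c1`, which gives 2550 mL.min-1.g-1, while compound 2 `C#Cc1cccc(N2C(=O)CSC2c2cccc(C(=O)NCCCCc3ccccc3)c2)c1`, at 751 mL.min-1.g-1, has the lowest number of the three. The next structure is compound 4 `CC(F)(F)c1cccc(N2C(=O)CSC2c2cccc(C(=O)NCCCCc3ccccc3)c2)c1`, and its difference from compound 3 is this: a group of 10 heavy atoms (8 carbon, 2 fluorine; one six-membered aromatic ring of carbon only) in place of a group of 7 heavy atoms (6 carbon, 1 fluorine; one six-membered aromatic ring of carbon only), on an amide-type nitrogen in a ring. The 2-fluorophenyl leaves, and the incoming group takes its place on the amide-type nitrogen in a ring.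

The measured steps at this same nitrogen are the best guide. One of them, a 1.5-fold lower number from compound 1 to compound 3 (0.17 log units; within the scatter), is small, whereas a 2.3-fold higher number from compound 2 to compound 3 (0.36 log units; beyond the scatter) and a 3.4-fold lower number from compound 1 to compound 2 (0.53 log units; beyond the scatter) are modest, and both of those involve compound 2. Within the data shown here, no measured compound carries the incoming group, so the data point in no clear direction, and no change beyond the scatter is expected. The expected step is a 1.1-fold lower number from compound 3 to compound 4 (0.03 log units; within the scatter). For compound 4 the estimated value is 1600 mL.min-1.g-1, with an expected range from 700 mL.min-1.g-1 to 3400 mL.min-1.g-1.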

Compound 4, intrinsic clearance in microsomes in the Homo sapiens assay: 1750 mL.min-1.g-1
Beside the measured number, compound 4's estimate is 1.1-fold (0.04 log units) below it, within the range that was stated.
By their numbers in the Homo sapiens assay, from the lowest: compound 2; then compounds 3, 4 and 1 (each within the scatter of the next).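

In the Homo sapiens assay, the group with the 1,1-difluoroethyl on the amide-type nitrogen in a ring reads much like the 2-fluorophenyl and the 3-methylphenyl, with a 1.0-fold higher number from compound 3 to compound 4 (0.01 log units; within the scatter) and a 1.5-fold lower number from compound 1 to compound 4 (0.16 log units; within the scatter), while the ethynyl compound stays apart, with a 2.3-fold higher number from compound 2 to compound 4 (0.37 log units; beyond the scatter). Among these four compounds, then, only compound 2 stands clear of the others in this assay, and the larger group brings no shift in either direction. The same swap does register in a physicochemical assay for solubility, read by turbidimetry, measured as kinetic solubility, at pH 7.4 (a lower number here means a less soluble compound, a higher number a more soluble compound), where compound 3 gives 10000 nM and compound 4 gives 2000 nM, and it goes with a loss of solubility: the measured solubility of compound 3, 10000 nM, and of compound 4, 2000 nM, a 5.0-fold lower number (0.70 log units; beyond the scatter)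

As far as these compounds go, it remains open how an amine or a carboxylic acid on this aromatic ring would read in the Homo sapiens assay and the physicochemical assay. The compounds shown also cannot tell whether the 1,1-difluoroethyl alone accounts for the drop in solubility, as the fluorine on the ring changes in the same step.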